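Swapping Methoxy for Methylsulfanyl in Compound 2

The source may hold more compounds than are shown below. What is called first, only, known or untested is meant among the compounds shown, and "the series" means these compounds.

Of the compounds shown here, two have so far been measured in an assay on a protein complex for inhibition of ubiquitin carboxyl-terminal hydrolase 1/WD repeat-containing protein 48 (Homo sapiens), read by fluorescence; on this read-out higher numbers stand for weaker inhibition and lower numbers for stronger inhibition. Compound 1 `FC(F)(F)c1ccccc1-c1nc(NCc2ccc(-c3ccc(Cl)cc3)cc2)c2ccccc2n1` gives 3600 nM. Compound 2 `COc1cnc(-c2ccccc2C(C)C)nc1NCc1ccc(-c2cccnc2)cc1` gives 70 nM, the lower of the two numbers, with compound 1 sitting at a higher number by a gap beyond the usual scatter. Compound 3 `CSc1cnc(-c2ccccc2C(C)C)nc1NCc1ccc(-c2cccnc2)cc1` differs from compound 2 in one place: methylsulfanyl in place of methoxy on an aromatic carbon. Among the compounds with values here, no measured pair shows this particular change, so only a modest step is expected, in either direction or none beyond the scatter. Compound 3 is therefore estimated at 90 nM, within 30 nM to 300 nM, which corresponds to an expected step of a 1.3-fold higher number from compound 2 to compound 3 (0.11 log units; within the scatter).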

Compound 3, half-maximal inhibitory concentration: 110 nM
Compound 3: middle estimate off by 1.2-fold (0.09 log units), on the low side; measured number inside the range.
By their numbers in this assay, from the lowest: compounds 2 and 3 (each within the scatter of the next); then compound 1.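

In this assay, replacing the oxygen of methoxy with the sulfur of methylsulfanyl gives a 1.6-fold higher number from compound 2 to compound 3 (0.20 log units; within the scatter). On this aromatic carbon, para to the 2-isopropylphenyl group, the two groups therefore cannot be told apart by this read-out, so this one-atom swap is tolerated. Within the data shown here, this is the first direct view of this position, as compound 1 differs from compound 2 in more than one place. Still open, going by these compounds, is how an amine, a hydroxyl group or a longer chain such as ethoxy would fare here. No further measurement bears on this result.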